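The source may hold more compounds than are shown below. What is called first, only, known or untested is meant among the compounds shown, and "the series" means these compounds.

In a functional assay on the whole organism for inhibition, with Rattus norvegicus as the target, read by paw edema, with stated times of 30 min and 4 h, at a dose of 0.28 mmol/kg by the oral route (on this read-out lower numbers stand for less inhibition and higher numbers for more inhibition at the one dose given (going by the name of the read-out)), compound 1 `CNC(=O)c1nc(-c2cc(OC)c(OC)c(OC)c2)n(-c2ccc(OC)cc2)n1` gives 65%, while compound 2 `COc1ccc(-n2nc(C(=O)Nc3ccccc3OC)nc2-c2cc(OC)c(OC)c(OC)c2)cc1` gives 24%, the lower of the two numbers seen so far. Compound 3 `COc1ccc(-n2nc(C(=O)Nc3cccc(F)c3)nc2-c2cc(OC)c(OC)c(OC)c2)cc1` differs from compound 2 in a single place: 3-fluorophenyl in place of 2-methoxyphenyl on an amide-type nitrogen. Among the compounds with values here, the one measured step touching the same amide-type nitrogen is a number 41 percentage points lower from compound 1 to compound 2 (beyond the scatter), where 2-methoxyphenyl took the place of methyl; the present change swaps one six-membered aromatic ring for another, so a shift of that size is not expected. The expected step is a number 6 percentage points higher from compound 2 to compound 3 (within the scatter), within or near the scatter. Compound 3 is therefore estimated at 30%, between 10% and 55%.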

Compound 3, a percentage reported as inhibition, in the whole organism at one dose (the size of the read-out at that dose, not a potency): 70%
Compound 3: the middle estimate sits 40 percentage points below what was measured, and the stated range ends below it.
By their numbers in this assay, from the lowest: compound 2; then compounds 1 and 3 (each within the scatter of the next).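

In this assay, the ring on the amide-type nitrogen matters and not only its presence: exchanging one six-membered aromatic ring for another gives a number 46 percentage points higher from compound 2 to compound 3 (beyond the scatter). An aromatic ring at this place therefore does not by itself bring a low number, as methyl against 3-fluorophenyl gives a number 5 percentage points higher from compound 1 to compound 3 (within the scatter). No measurement here explains the step.

Still open, from the compounds shown here alone, is whether the step follows from the methoxy group leaving, the fluorine entering, or where each sits on the ring. Unsubstituted phenyl, 2-fluorophenyl and 3-methoxyphenyl on this nitrogen would help to separate these.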